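This account rests on a few compounds, and the source may have more. Where it says the series, first, only, none or still open, it means among the compounds named here.

The series shares one core, carried by compound 1 `COc1ccc(-n2cc3nc(-c4ccccc4)nc(N)c3n2)cc1`, compound 2 `COc1ccc(-n2cc3nc(C)nc(NC(=O)Nc4ccccc4)c3n2)cc1` and compound 3 `Cc1nc(NC(=O)Nc2ccccc2)c2nn(-c3ccccc3)cc2n1`. In an assay on CHO cells for displacement of a labelled ligand from adenosine receptor A1 (Homo sapiens), read by scintillation counting, with a stated time of 120 min, tested at 1 uM (on this read-out higher numbers stand for more inhibition at the one concentration tested (going by the name of the read-out) and lower numbers for less inhibition), compound 1 gives 12%. In this assay compound 2 gives 5%, and compound 3 gives 1%. Compound 2 thus sits among three numbers none of which is separated from another beyond the scatter: its nearest neighbour is compound 3, its furthest compound 1. Going by the values given here, the only step measured in one place, a number 4 percentage points lower from compound 2 to compound 3 (within the scatter), concerns hydrogen in place of methoxy on an aromatic carbon and is within the scatter. Compound 4 `COc1ccc(-n2cc3nc(C)nc(NC(=O)c4ccco4)c3n2)cc1` differs from compound 2 by furan-2-yl in place of anilino on a carbonyl carbon. Among the compounds with values here, no measured step touches the carbonyl carbon or the group on it, so the only guide is that every change seen so far in this assay has left the number within the scatter. The step from compound 2 to compound 4 is therefore expected to be small, no change at the digits printed from compound 2 to compound 4 (within the scatter), with no direction favoured. Compound 4 is estimated at 5%, in the range -5% to 15%.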

Compound 4, a percentage reported as inhibition, at one concentration (the size of the read-out at that concentration, not a potency): 6%
Compound 4: the middle estimate sits 1 percentage points below what was measured, within the range that was stated.
By their numbers in this assay, from the lowest: compounds 3, 2, 4 and 1 (each within the scatter of the next, the first and the last beyond it).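

Going by these compounds alone, the change on the carbonyl carbon, furan-2-yl in place of anilino, gives a number 1 percentage points higher from compound 2 to compound 4 (within the scatter) in this assay and is the only measured step at this position. It exchanges a six-membered carbon ring carrying a hydrogen-bond donor for a five-membered ring with one hetero atom and a hydrogen-bond acceptor, and this read-out at one concentration does not separate the two groups. Nothing available explains this outcome.

Open, on these data alone, is whether an amine, a carboxylic acid or a longer chain on this carbonyl carbon would move the number beyond the scatter. Also open, as far as these compounds go, is whether furan-2-yl in place of anilino would give a similar step with hydrogen in place of methoxy on the aromatic carbon, as in compound 3.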